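The source may hold more compounds than are shown below. What is called first, only, known or untested is meant among the compounds shown, and "the series" means these compounds.

Compound 1 `CCOC(=O)c1ccc(-c2nn(Cc3cccc(Cl)c3)c3ccccc23)cc1`. In a functional assay on cells (Platelet, Homo sapiens) for inhibition (a lower number here means a stronger inhibitor, a higher number a weaker inhibitor), compound 1 gives > 10000 nM, a limit of the assay.
Compound 2 `CCOC(=O)c1ccc(-c2nn(Cc3cccc(F)c3)c3ccccc23)cc1`. In this assay compound 2 gives > 10000 nM, a limit of the assay.
Compound 3 `CCOC(=O)c1ccc(-c2nn(-c3ccoc3)c3ccccc23)cc1`. In this assay compound 3 gives > 10000 nM, a limit of the assay.

Compound 3 thus stands only at a limit, as do the other two values; all three sit at the limit of > 10000 nM in this assay, at which 3 of the 3 values shown sit. The measured steps a step that the two limits leave unreadable from compound 1 to compound 2, a step that the two limits leave unreadable from compound 1 to compound 3 and a step that the two limits leave unreadable from compound 2 to compound 3 are unreadable in size for the same reason.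

Compound 4 `CCOC(=O)c1ccc(-c2nn(-c3ccccc3)c3ccccc23)cc1` differs from compound 3 by phenyl in place of furan-3-yl on an aromatic nitrogen. Within the data shown here, no measured step bears on the switch from furan-3-yl to phenyl on the aromatic nitrogen, and the step that the limit leaves unreadable from compound 3 to compound 4 is therefore an expectation only, most likely none beyond the scatter. Compound 4 is estimated at 20000 nM in this assay, within 5000 nM to 80000 nM, with a limit again the probable outcome.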

Compound 4, half-maximal inhibitory concentration: > 10000 nM
Compound 4 gave a limit, no number (the forecaster's own chance of this, stated with the estimate: 85%); the middle value does not contradict the limit.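

Compound 4 is a limit, as are compound 1, compound 2 and compound 3, so its steps from those three cannot be read: the limit of > 10000 nM in this assay, at which 4 of the 4 values shown sit.

The compounds shown leave open whether any group on the aromatic nitrogen gives a readable value in this assay.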